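The source may hold more compounds than are shown below. What is called first, only, known or untested is meant among the compounds shown, and "the series" means these compounds.

Compound 1 `O=C(CN1C(=O)/C(=C/c2ccc(-c3ccc(Cl)cc3)o2)SC1=S)NCc1ccc(F)cc1` gives 165000 nM in a functional assay on REH cells (Homo sapiens) for cytotoxicity, read by MTT assay, with a stated time of 72 h (on this read-out lower numbers stand for stronger inhibition and higher numbers for weaker inhibition), the higher of the two numbers recorded so far. Among the compounds with values here, compound 2 `O=C(CN1C(=O)/C(=C/c2ccc(-c3ccc(Cl)cc3)o2)SC1=S)NCc1ccc(Br)cc1` gives 75000 nM in this assay, and the step of a 2.2-fold lower number from compound 1 to compound 2 (0.34 log units; beyond the scatter) is the only measured change on this part of the molecule. Compound 3 `O=C(CN1C(=O)/C(=C/c2ccc(-c3ccc(Cl)cc3)o2)SC1=S)NCc1ccccc1Cl` differs from compound 1 by 2-chlorophenyl in place of 4-fluorophenyl on a saturated chain carbon bound to an amide-type nitrogen. That single halogen exchange is the nearest guide, but it is not the same change, so only a modest move toward a lower number is expected. Compound 3 is expected at 100000 nM, within 40000 nM to 250000 nM, which means a step of a 1.7-fold lower number from compound 1 to compound 3 (0.22 log units; within the scatter).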

Compound 3, half-maximal inhibitory concentration: 70000 nM
For compound 3 the middle estimate is 1.4-fold (0.15 log units) above the measured one; the measured number falls inside the stated range.
By their numbers in this assay, from the lowest: compounds 3 and 2 (each within the scatter of the next); then compound 1.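

Replacing 4-fluorophenyl with 2-chlorophenyl at this position gives a 2.4-fold lower number from compound 1 to compound 3 (0.37 log units; beyond the scatter) and so shows that a lower number does not depend on 4-bromophenyl alone. Replacing 4-bromophenyl with 2-chlorophenyl gives a 1.1-fold lower number from compound 2 to compound 3 (0.03 log units; within the scatter) and leaves compounds 2 and 3 without an order, while compound 1 stands apart from both. No evidence accounts for these steps.

The compounds shown leave open how unsubstituted phenyl or 4-chlorophenyl would compare here. They also leave open whether a phenyl ring carrying an amine or a carboxylic acid would be tolerated.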